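A few compounds are considered here, and "the series" means these few. Any claim that something is new, unique, unknown or untested is made for them only; others in the source may bear on it.

Measured so far in the series:

compound 1, `Nc1ccccc1NC(=O)c1ccc(CSC(=S)N2CCCc3ccccc32)cc1`, giving 26.1%
compound 2, `Nc1ccccc1NC(=O)c1ccc(CSC(=S)N(Cc2ccccc2)Cc2ccccc2)cc1`, giving 1%

Both were run in a functional assay on HeLa cells (Homo sapiens) for antiproliferative activity, read by CCK-8 assay, with a stated time of 72 h, tested at 2 uM; a higher number here means a stronger effect of the compound at the concentration tested, a lower number a weaker effect. Compound 1 holds the higher of the two numbers; the gap to compound 2 lies beyond the usual scatter of repeated runs, so the two are distinguishable on the present data, though two points give no trend.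

The next compound, compound 3, `CN1CCN(C(=S)SCc2ccc(C(=O)Nc3ccccc3N)cc2)CC1`, is not yet measured. It differs from compound 1 by 4-methylpiperazin-1-yl in place of 1,2,3,4-tetrahydroquinolin-1-yl on a thiocarbonyl carbon. Among the measured compounds shown here, no measured pair shows this exchange, so there is no step on record to lean on; the only guidance is that compound 1 sits above compound 2 and that the exchange is a change of the group attached to the thiocarbonyl carbon, the same position that separates compound 1 from compound 2.

With that in mind, a small step downward is expected, one that may stay within the scatter: the expected step is a number 11.1 percentage points lower from compound 1 to compound 3 (beyond the scatter). For compound 3 the estimate in this assay is 15%, expected to fall between 0% and 38%.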

Compound 3, a percentage reported as inhibition, at one concentration (the size of the read-out at that concentration, not a potency): 52.6%
For compound 3 the middle estimate is 37.6 percentage points below the measured one, outside the stated range (above it).
By their numbers in this assay, from the lowest: compound 2; then compound 1; then compound 3.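

In this assay, the group on the thiocarbonyl carbon emerges as a sensitive point in the series: 4-methylpiperazin-1-yl in place of 1,2,3,4-tetrahydroquinolin-1-yl gives a number 26.5 percentage points higher from compound 1 to compound 3 (beyond the scatter). The six-membered aromatic ring of the group leaving is therefore not required for this read-out, since compound 3 gives 52.6% with a single non-aromatic ring carrying two hetero atoms. The exchange alters the ring type, the hetero atom count, the acceptor count and the heavy atom count together, and no supporting measurement on record accounts for the step or separates these changes.

From the compounds shown here alone, it remains open whether the second ring nitrogen or the methyl on it matters, a question that morpholin-4-yl, with an oxygen in that ring position, piperidin-1-yl, with a carbon there, and 4-ethylpiperazin-1-yl could each help to address. A read-out at one concentration also gives no potency, so the size of this step cannot be translated into a potency difference between compound 1 and compound 3.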